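Replacing the methoxyphenyl ketone partner with a difluorophenyl group

This account rests on a few compounds, and the source may have more. Where it says the series, first, only, none or still open, it means among the compounds named here.

Measured compounds:
compound 1, `COc1cc(-c2cc(/C=C/C(=O)c3ccc(N)cc3)[nH]n2)cc(OC)c1OC`: -91%
compound 2, `COc1ccc(C(=O)/C=C/c2cc(-c3cc(OC)c(OC)c(OC)c3)n[nH]2)cc1`: -82%

Of the compounds shown here, two sharing one core have been tested in a functional assay on HCC 2998 cells (Homo sapiens) for cytotoxicity, read by sulforhodamine B assay, with a stated time of 48 h, tested at 100 uM; a higher number here means a weaker effect of the compound at the concentration tested, a lower number a stronger effect. In this assay compound 1 gives -91%, and compound 2 gives -82%. Going by the values given here, compound 2 carries the higher of the two numbers, but the only step between them, a number 9 percentage points higher from compound 1 to compound 2 (within the scatter), lies within the scatter, so the two compounds cannot be told apart on these numbers.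

Compound 3, `COc1cc(-c2cc(/C=C/C(=O)c3ccc(F)c(F)c3)[nH]n2)cc(OC)c1OC`, differs from compound 2 in one place: 3,4-difluorophenyl in place of 4-methoxyphenyl on a carbonyl carbon. Among the compounds with values here, no measured step touches this change. Within the data shown here, the single step known, from compound 1 to compound 2, concerns a different group at a different place and itself stays within the scatter, so it offers no direction for the new exchange. The account therefore rests on the two measured values alone, both of which show strong effects at the concentration tested.

On that basis the step is expected to stay within the scatter: a number 3 percentage points lower from compound 2 to compound 3 (within the scatter). The value estimated for compound 3 is -85%, in a range from -100% to -55%.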

Compound 3, a percentage reported as activity, at one concentration (the size of the read-out at that concentration, not a potency): -11%
Estimate against measurement, compound 3: 74 percentage points below, outside the stated range (above it).
By their numbers in this assay, from the lowest: compounds 1 and 2 (each within the scatter of the next); then compound 3.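

The group on the carbonyl carbon, which could not be told apart between the earlier two compounds, proves decisive in this assay: 3,4-difluorophenyl in place of 4-methoxyphenyl gives a number 71 percentage points higher from compound 2 to compound 3 (beyond the scatter), and the same group in place of 4-aminophenyl gives a number 80 percentage points higher from compound 1 to compound 3 (beyond the scatter). The 4-aminophenyl and 4-methoxyphenyl groups thus stay together on one side, while compound 3, at -11%, stands well apart from both, so this position tolerates some exchanges at the concentration tested but not all of them. No measurement at hand bears on why this exchange has so large a consequence.

From the compounds shown here alone, whether a plain phenyl, a hydroxyphenyl or a dimethylaminophenyl group on the carbonyl carbon would side with compound 1 and compound 2 or with compound 3 remains open, as does the question of whether a single fluorine would behave like the pair in 3,4-difluorophenyl. The compounds shown also leave open whether the gap would hold at lower concentrations or in other cell lines, since all three were read at one concentration on one line.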